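Removing the phenyl from the imidazole nitrogen of compound 1

This account rests on a few compounds, and the source may have more. Where it says the series, first, only, none or still open, it means among the compounds named here.

Within the data shown here, compound 1 `c1ccc(-n2cnc3cc4c(cc32)C2CNCC4C2)cc1` gives the lowest number of the three compounds measured so far in an assay on HEK293 cells for binding affinity to Neuronal acetylcholine receptor; alpha4/beta2 (Homo sapiens) (on this read-out lower numbers stand for stronger inhibition and higher numbers for weaker inhibition), with 0.14 nM. Compound 2 `Fc1cc2c(cc1F)C1CNCC2C1` gives 0.28 nM in this assay, a difference from compound 1 that lies within the scatter, so the two cannot be told apart. Compound 3 `Oc1cccc2c1C1CNCC2C1` gives 1700 nM, far beyond the scatter from compound 1.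

Compound 4 `c1nc2cc3c(cc2[nH]1)C1CNCC3C1` differs from compound 1 by one change: hydrogen in place of phenyl on an aromatic nitrogen. Among the measured compounds shown here, no measured pair shows this change, so the size of the step in this assay cannot be read from the other compounds. Given that compound 1 gives 0.14 nM and compound 2 gives 0.28 nM, the core of compound 1 alone appears to carry strong binding, and compound 4 is expected to stay close to compound 1, with perhaps a small step toward a higher number, a 2.5-fold higher number from compound 1 to compound 4 (0.40 log units; beyond the scatter), that may not exceed the scatter. The estimate for compound 4 is 0.35 nM, in the range 0.06 nM to 2.5 nM.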

Compound 4, inhibition constant: 0.15 nM
Compound 4: middle estimate off by 2.3-fold (0.37 log units), on the high side, and the stated range covers the measured number.
By their numbers in this assay, from the lowest: compounds 1, 4 and 2 (each within the scatter of the next); then compound 3.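

In this assay, hydrogen in place of phenyl on an aromatic nitrogen gives a 1.1-fold higher number from compound 1 to compound 4 (0.03 log units; within the scatter), so compound 1 and compound 4 cannot be told apart. Among these compounds, this is the first direct reading at this position: with the phenyl and its 6 heavy atoms gone, the number stays within the scatter, so the phenyl is not needed for the binding seen on this read-out. No measurement at hand bears on the reason for this result.

Only hydrogen and phenyl are shown on this nitrogen, so it remains open whether a methyl, a longer chain such as butyl, or a benzyl would also leave the number within the scatter. From the compounds shown here alone, it is equally open whether a chain ending in an amine or a carboxylic acid would be accepted there.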